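This account rests on a few compounds, and the source may have more. Where it says the series, first, only, none or still open, it means among the compounds named here.

Four compounds built on one shared core belong to this set, and only one of them has a reported number. Compound 1 `COc1ccc2nc(-c3ccccc3)cc(-c3ccccc3)c2c1` is that one: in a functional assay on Hep2C cells (Homo sapiens) for antiproliferative activity, read by MTT assay, with a stated time of 24 h (on this read-out higher numbers stand for weaker inhibition and lower numbers for stronger inhibition), compound 1 gives 496000 nM, which counts as weak inhibition. Compound 2 `O=[N+]([O-])c1cccc(-c2cc(-c3ccccc3)c3cc(Br)ccc3n2)c1` carries a bromine and a nitro group; in this assay compound 2 gives "not determined" (no result reported), so compound 2 stands nowhere on the numbers. Compound 3 `Oc1ccc2c(-c3ccccc3)cc(-c3ccccc3)nc2c1` likewise has no reported result: in this assay compound 3 gives "not determined" (no result reported). The new compound is compound 4 `Brc1ccc2nc(-c3ccccc3)cc(-c3ccccc3)c2c1`, which differs from compound 2 in one place: hydrogen in place of nitro on an aromatic carbon. For the measured compounds named here, compound 2 has no number, so no step between measured compounds exists, and neither the size nor the direction of any change from compound 2 to compound 4 in this assay can be read from the data. Going by the values given here, the only anchor is compound 1, which shares the core of compound 4. Weak inhibition is expected for compound 4 as well, because compound 1 with the same core gives 496000 nM. The estimate for compound 4 is 400000 nM, within a range from 100000 nM to 1500000 nM.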

Compound 4, half-maximal inhibitory concentration: 128000 nM
For compound 4 the middle estimate is 3.1-fold (0.49 log units) above the measured one, and the stated range covers the measured number.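

In this assay, for the compounds shown here, the change of methoxy to bromo on an aromatic carbon of the shared core gives a 3.9-fold lower number from compound 1 to compound 4 (0.59 log units; beyond the scatter) and this is the first step in the set that can be read. It shows that the number responds to the group at this position, with bromo giving the stronger inhibition of this pair, although the step is modest and rests on a single pair of compounds. Nothing measured here explains the shift.

Steps involving compound 2 or compound 3 cannot be read, so the effect of removing the nitro group remains unknown. Going by these compounds, it also remains open how an amine or a carboxylic acid at the bromo position would compare with compound 4.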